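The source may report more compounds than this note shows. Statements on the series, on what has been measured and on what is new or still open speak of the compounds shown alone.

Measured so far:
- compound 1, `O=C(CSc1nnc(Br)n1Cc1ccc(Br)c2ccccc12)NO`, gives 640 nM in an assay on HEK293 cells for inhibition of solute carrier family 22 member 12 (Homo sapiens); a lower number here means a stronger inhibitor, a higher number a weaker inhibitor
- compound 2, `O=S(=O)(CSc1nnc(Br)n1Cc1ccc(Br)c2ccccc12)Nc1ccc(Cl)nc1`, gives 1940 nM in this assay

Both compounds share the same core and differ only in the group attached to it. For the measured compounds named here, of the two numbers known, compound 2 has the higher one, and the gap to compound 1 is beyond the usual scatter, so compound 2 is the weaker inhibitor of the pair. Going by the values given here, nothing in these two compounds isolates the effect of a single change, so no measured step is available to lean on.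

Compound 3, `COc1ncccc1NS(=O)(=O)CSc1nnc(Br)n1Cc1ccc(Br)c2ccccc12`, has not yet been measured. It differs from compound 2 in one place: 2-methoxypyridin-3-yl in place of 6-chloropyridin-3-yl on a sulfonamide nitrogen. Both groups are six-membered aromatic rings with one hetero atom, and the swap is confined to the group on the sulfonamide nitrogen, while the rest of the molecule is unchanged. Among the compounds with values here, with no measured step of this kind to compare against, the expectation is that the step of a 1.0-fold higher number from compound 2 to compound 3 (0.01 log units; within the scatter) stays within the scatter, in no particular direction. Compound 3 is therefore estimated at 2000 nM in this assay, with a range from 700 nM to 6000 nM.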

Compound 3, half-maximal inhibitory concentration: 4050 nM
For compound 3 the middle estimate is 2.0-fold (0.31 log units) below the measured one; the range from low to high includes it.
By their numbers in this assay, from the lowest: compound 1; then compound 2; then compound 3.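

In this assay, the group on the sulfonamide nitrogen matters: 2-methoxypyridin-3-yl in place of 6-chloropyridin-3-yl gives a 2.1-fold higher number from compound 2 to compound 3 (0.32 log units; beyond the scatter), which makes compound 3 the weaker inhibitor of this pair. The earlier compounds shown here could not show this, as they offered no comparison of a single change. Both groups are six-membered aromatic rings with one hetero atom and no net charge, so even a swap between such similar groups moves the number beyond the usual scatter, though only modestly, and nothing measured here explains why.

This one step changes several things at once, the chlorine leaving, the methoxy group arriving and the place of the substituent on the ring, so it cannot say which of them accounts for the higher number. On these data alone, how a plain pyridin-3-yl group carrying neither substituent, or a phenyl group, would compare on the same sulfonamide nitrogen remains open, as does whether the step would keep its size and direction on a different core.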